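A few compounds are considered here, and "the series" means these few. Any claim that something is new, unique, unknown or untested is made for them only; others in the source may bear on it.

Compound 2, whose structure is `COc1cc(-c2cc(-c3cc(C(C)C)c(O)cc3C)[nH]c(=O)c2C#N)ccc1O`, was examined in a functional assay for inhibition, tested at 40 ug/mL (on this read-out lower numbers stand for a weaker effect and higher numbers for a stronger effect at the one concentration tested), where compound 2 gives 32%. Compound 1, with the structure `COc1cccc(-c2cc(-c3cc(C(C)C)c(O)cc3C)[nH]c(=O)c2C#N)c1`, differs from it only by hydroxy in place of hydrogen on an aromatic carbon; in this assay compound 1 gives 30%. The single measured step, a number 2 percentage points higher from compound 1 to compound 2 (within the scatter), is within the scatter, so compound 2 stands at the same level as compound 1 on the numbers shown and neither can be called the stronger.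

Compound 3, with the structure `Cc1cc(O)c(C(C)C)cc1-c1cc(-c2ccccc2Cl)c(C#N)c(=O)[nH]1`, has not yet been measured. Its difference from compound 2 is 2-chlorophenyl in place of 4-hydroxy-3-methoxyphenyl on an aromatic carbon. Among the measured compounds shown here, the only measured step concerns a hydroxy for hydrogen on the aromatic carbon of the shared aryl group, not the exchange of one aryl group for another, so it does not bear directly on this change, and the measured pair sets no direction for it. With that, compound 3 is expected to give a result in this assay close to that of compound 2, with the step estimated as a number 2 percentage points lower from compound 2 to compound 3 (within the scatter) and a wide range. The estimate for compound 3 in this assay is 30%, with a range from 10% to 55%.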

Compound 3, a percentage reported as inhibition, at one concentration (the size of the read-out at that concentration, not a potency): 20%
Compound 3: middle estimate off by 10 percentage points, on the high side, and the stated range covers the measured number.
By their numbers in this assay, from the lowest: compounds 3, 1 and 2 (each within the scatter of the next, the first and the last beyond it).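

In this assay, among the compounds shown here, putting 2-chlorophenyl in place of 4-hydroxy-3-methoxyphenyl, on the aromatic carbon opposite the ring nitrogen and ortho to the cyano group, gives a number 12 percentage points lower from compound 2 to compound 3 (beyond the scatter); this is the first step beyond the scatter and shows that exchanging the whole aryl group at this position can move the read-out, which the hydroxy for hydrogen step did not show. The effect is modest and depends on the group replaced: 2-chlorophenyl in place of 3-methoxyphenyl at the same position gives a number 10 percentage points lower from compound 1 to compound 3 (within the scatter), so that pair cannot be told apart on these numbers. Nothing available explains the difference between these aryl groups.

From the compounds shown here alone, the exchange removes the hydroxy and methoxy groups and adds a chlorine in a single step, so the contribution of each to the result remains open. Also open, going by these compounds, is how the read-out would respond at this position to an unsubstituted phenyl, or to a phenyl carrying an amine or a carboxylic acid.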